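The source may hold more compounds than are shown below. What is called first, only, known or untested is meant among the compounds shown, and "the series" means these compounds.

Compound 1, `CC(C)[C@H](NC(=O)CN(c1nc(Cl)nc2[nH]cnc12)C1CC1)C(=O)OCc1ccccc1`, was tested in a functional assay on the whole organism (Tail, strain ICR) with Mus musculus as the target, in the tail flick test, with a stated time of 150 min, at a dose of 25 umol/kg by the oral route (a lower number here means a weaker effect, a higher number a stronger effect of the compound at the dose given), where compound 1 gives 17.9%. This is the lower of the two numbers available. For the measured compounds named here, the only comparison is compound 2, `O=C(O)CC[C@H](NC(=O)CN(c1nc(Cl)nc2[nH]cnc12)C1CC1)C(=O)O`, which in this assay gives 29.5%, a difference that goes beyond the usual scatter of the measurement; no single-point step connects these two compounds, so the gap is simply noted.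

Compound 3, `CC[C@H](C)[C@H](NC(=O)CN(c1nc(Cl)nc2[nH]cnc12)C1CC1)C(=O)OCc1ccccc1`, has not yet been measured. It differs from compound 1 in one place: methyl in place of hydrogen on a saturated chain carbon, three bonds along the chain from an amide-type nitrogen and a carbonyl carbon. Cut one bond further out, the same change reads isopropyl to sec-butyl. Nothing measured speaks to this change, so the expectation rests on compound 1 alone, and the step from compound 1 to compound 3 is expected to be small, a number 1.1 percentage points higher from compound 1 to compound 3 (within the scatter), not beyond the scatter. Compound 3 is therefore estimated at 19%, with a likely range from 8% to 32%.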

Compound 3, a percentage reported as activity, at one dose (the size of the read-out at that dose, not a potency): 6.9%
Compound 3: middle estimate off by 12.1 percentage points, on the high side, outside the stated range (below it).
By their numbers in this assay, from the lowest: compound 3; then compound 1; then compound 2.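

Going from isopropyl to sec-butyl at this saturated chain carbon is not a neutral change: in this assay the added methyl gives a number 11 percentage points lower from compound 1 to compound 3 (beyond the scatter). This shows that the position responds to one extra carbon, and that in this pair the response is a weaker effect at the dose given, something compound 1 alone could not reveal. Nothing available explains why the effect falls in the whole animal.

For the compounds shown here, with only this one step at this position, it remains open whether the effect would keep falling with a longer chain such as n-pentyl or a bulkier group such as tert-butyl. From the compounds shown here alone, it is also open whether a hydroxyl group or an amine on this chain would weaken the effect in the same way or restore it.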